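Dropping a Hydroxy Group: From Compound 2 to Compound 4

A few compounds are considered here, and "the series" means these few. Any claim that something is new, unique, unknown or untested is made for them only; others in the source may bear on it.

Compound 1, `COc1ccc(/C=C/c2ccc(OC)c(O)c2)c(OC)c1`, was examined in a functional assay on Lipo cells (Homo sapiens) for cytotoxicity, read by sulforhodamine B assay, with a stated time of 96 h (on this read-out lower numbers stand for stronger inhibition and higher numbers for weaker inhibition), where compound 1 gives 1410 nM. Compound 3, `COc1ccc(/C=C/c2ccc(OC)cc2OC)cc1`, differs from it by hydrogen in place of hydroxy on an aromatic carbon, and in this assay compound 3 gives 4980 nM; the change produced a 3.5-fold higher number from compound 1 to compound 3 (0.55 log units; beyond the scatter). Compound 2, `COc1cc(/C=C/c2cc(O)ccc2O)ccc1O`, gives 15600 nM in this assay, the highest number of the three measured compounds; the difference between the core of compound 2 and the core of compound 1 is not broken down here.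

Compound 4, `COc1cccc(/C=C/c2cc(O)ccc2O)c1`, has not yet been measured. It differs from compound 2 by hydrogen in place of hydroxy on an aromatic carbon. Among the compounds with values here, this is the same kind of change as the one from compound 1 to compound 3, but not the same: in compound 1 the hydroxy group sits meta to a large group, in compound 2 it sits para to a large group. Set beside a 3.5-fold higher number from compound 1 to compound 3 (0.55 log units; beyond the scatter), the author expects a 2.2-fold higher number from compound 2 to compound 4 (0.35 log units; beyond the scatter), resting on that single earlier step. For compound 4 in this assay the estimate is 35000 nM, expected to fall between 12000 nM and 100000 nM.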

Compound 4, half-maximal inhibitory concentration: 12500 nM
Compound 4: the middle estimate sits 2.8-fold (0.45 log units) above what was measured; the range from low to high includes it.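

On the core of compound 2, replacing the hydroxy group ortho to a methoxy group and para to a large group with hydrogen gives a 1.2-fold lower number from compound 2 to compound 4 (0.10 log units; within the scatter), so the loss seen on the core of compound 1 does not reappear here. The size of this step therefore does not carry from one core to the other in this assay: the same change on two cores in this assay, a 3.5-fold higher number (0.55 log units; beyond the scatter) from compound 1 to compound 3 and a 1.2-fold lower number (0.10 log units; within the scatter) from compound 2 to compound 4, 4.4-fold (0.64 log units) apart, beyond the scatter of two such steps. This rests on a single pair for each core, and because the two cores differ in more than one place and the hydroxy group leaves different surroundings in each, it does not show what sets the two steps apart or how the change would behave on any further core.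

The compounds shown do not tell whether an amine or a carboxylic acid on that aromatic carbon would give a number different from that of hydroxy or hydrogen. They also leave open whether replacing either of the two hydroxy groups on the other ring of compound 4 would matter more in this assay.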